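Chloro to bromo swap on the phenyl ring of compound 3

The source may hold more compounds than are shown below. What is called first, only, known or untested is meant among the compounds shown, and "the series" means these compounds.

Of the compounds shown here, three have been measured in a functional assay on SK-OV-3 cells (Homo sapiens) for inhibition, read by sulforhodamine B assay, with a stated time of 48 h, tested at 10 uM; a higher number here means more inhibition at the concentration tested (going by the name of the read-out), a lower number less inhibition. Compound 1 `c1ccc(-c2cn3ccnc3c(-c3ccc4ncn(C5CCCCC5)c4c3)n2)cc1` gives 7.52%. Compound 2 `O=Cc1ccc(-c2cn3ccnc3c(-c3ccc4ncn(C5CCCCC5)c4c3)n2)cc1` gives 5.11%, and compound 3 `Clc1ccc(-c2cn3ccnc3c(-c3ccc4ncn(C5CCCCC5)c4c3)n2)cc1` gives 6.14%. All three numbers sit close together: a number 2.4 percentage points lower from compound 1 to compound 2 (within the scatter), a number 1.4 percentage points lower from compound 1 to compound 3 (within the scatter) and a number 1 percentage points higher from compound 2 to compound 3 (within the scatter). Compound 3 thus holds the second highest of the three numbers, with compound 2 nearest and compound 1 furthest, but neither gap exceeds the scatter.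

Compound 4 `Brc1ccc(-c2cn3ccnc3c(-c3ccc4ncn(C5CCCCC5)c4c3)n2)cc1` is the next member. Compared with compound 3, (bromo in place of chloro on an aromatic carbon).

Going by the values given here, the steps that bear on this change are those that vary the same position: from hydrogen to chloro, a number 1.4 percentage points lower from compound 1 to compound 3 (within the scatter), and from formyl to chloro, a number 1 percentage points higher from compound 2 to compound 3 (within the scatter). Both were within the scatter. Exchanging one halogen for another at the same position is therefore expected to give no step beyond the scatter, a number 0.1 percentage points lower from compound 3 to compound 4 (within the scatter). Compound 4 is expected to give about 6% in this assay , within a range of 0% to 14%.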

Compound 4, a percentage reported as inhibition, at one concentration (the size of the read-out at that concentration, not a potency): 6.44%
Estimate against measurement, compound 4: 0.4 percentage points below; the measured number falls inside the stated range.
By their numbers in this assay, from the lowest: compounds 2, 3, 4 and 1 (each within the scatter of the next).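

In this assay, the change from 4-chlorophenyl to 4-bromophenyl, para to a large group, gives a small step: a number 0.3 percentage points higher from compound 3 to compound 4 (within the scatter). The two other steps to bromo read the same way, a number 1.3 percentage points higher from compound 2 to compound 4 (within the scatter) and a number 1.1 percentage points lower from compound 1 to compound 4 (within the scatter), so this assay at this single concentration does not separate hydrogen, formyl, chloro and bromo at this position. No measurement at hand gives a reason for these numbers.

From the compounds shown here alone, it remains open whether any group at this position can produce a step beyond the scatter, for example an amine, a carboxylic acid or a longer chain. Going by these compounds, whether a change elsewhere on the shared core would do so is also open.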